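A few compounds are considered here, and "the series" means these few. Any claim that something is new, unique, unknown or untested is made for them only; others in the source may bear on it.

Measured in a functional assay on KB cells (Homo sapiens) for antiproliferative activity, read by sulforhodamine B assay, with a stated time of 72 h; a lower number here means a stronger inhibitor, a higher number a weaker inhibitor:
- compound 1 `COc1c(OC(C)C)cc2occ(-c3csc4ccccc34)c(=O)c2c1OC(C)C`: > 10000 nM (a limit)
- compound 2 `COc1cc2occ(-c3csc4ccccc34)c(=O)c2c(OC)c1OC`: 820 nM
- compound 3 `COc1cc2occ(-c3csc4ccccc34)c(=O)c2c(OC)c1O`: > 10000 nM (a limit)

Compound 3 gives only a limit and sits at the limit of > 10000 nM in this assay, at which 2 of the 3 values shown sit. Compound 4 `CCOc1c(OC)cc2occ(-c3csc4ccccc34)c(=O)c2c1OC` carries ethyl in place of hydrogen on an oxygen on an aromatic ring, that is, hydroxy to ethoxy. For the measured compounds named here, the one measured step bearing on this is an at least 12-fold higher number from compound 2 to compound 3 (1.08 log units; beyond the scatter), a large loss on freeing the same oxygen. Capping that oxygen again should therefore recover much of the loss in this assay, with compound 2 at 820 nM as the nearest measured reference. Compound 1 also has no free hydroxy yet remains a limit, so full recovery is not assured. The expected change is large and toward a lower number: an at least 6.6-fold lower number from compound 3 to compound 4 (0.82 log units; beyond the scatter). For compound 4 the estimated value is 1500 nM, with an expected range of 500 nM to 6000 nM.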

Compound 4, half-maximal inhibitory concentration: 4000 nM
For compound 4 the middle estimate is 2.7-fold (0.43 log units) below the measured one; low and high end bracket the measured number.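

In this assay, ethoxy in place of hydroxy on this oxygen brings a measurable value back, with an at least 2.5-fold lower number from compound 3 to compound 4 (0.39 log units; beyond the scatter). Capping alone does not settle the outcome, since going from methyl to ethyl on the same oxygen gives a 4.9-fold higher number from compound 2 to compound 4 (0.69 log units; beyond the scatter), so the identity of the cap counts as well as the loss of the free hydroxy. Compound 3 is a limit, so the first step is only a bound: the limit of > 10000 nM in this assay, at which 2 of the 4 values shown sit.

Going by these compounds, how a propyl chain, or a chain ending in an amine, would read on this oxygen stays open.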